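Trimming a Methoxy Group Ahead of a Cytotoxicity Reading

The compounds below may be only part of what the source reports. "The series", "measured", "known", "first", "only" and "open" are said of these compounds alone.

The account concerns two hydrazone derivatives built on a shared naphthyloxyacetyl hydrazide core and tested in an ADME assay on HEL cells (Homo sapiens) for cytotoxicity; on this read-out lower numbers stand for higher toxicity in this test and higher numbers for lower toxicity in this test. Compound 1, `C/C(=N\NC(=O)COc1cccc2ccccc12)c1ccc(C#N)cc1Br`, gives 20 ug/mL in this assay. Compound 2, `COc1cc(/C=N/NC(=O)COc2cccc3ccccc23)cc(OC)c1OC`, carries three methoxy groups on its aromatic ring. For compound 2 this assay reports only a limit, >= 20 ug/mL, rather than a number. The two values therefore sit in the same region, and compound 2 is one of the compounds at the limit of >= 20 ug/mL in this assay, at which 1 of the 2 values shown sits.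

The unmeasured compound 3, `COc1ccc(/C=N/NC(=O)COc2cccc3ccccc23)cc1OC`, departs from compound 2 by a single change: hydrogen in place of methoxy on an aromatic carbon. Within the data shown here, no step between two measured compounds is available to calibrate this change. Given that compound 2 stands at the limit of >= 20 ug/mL in this assay, at which 1 of the 2 values shown sits, the author expects the step from compound 2 to compound 3 to be a number no higher from compound 2 to compound 3 (the limit leaves the size open), that is, none beyond the usual scatter, with a fair chance that the assay again returns only a limit. Compound 3 is accordingly estimated at 20 ug/mL in this assay, within a range from 10 ug/mL to 40 ug/mL.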

Compound 3, minimum cytotoxic concentration in the HEL assay: >= 20 ug/mL
Compound 3 ended at the assay's limit; the forecaster's own chance of this, stated with the estimate: 55%; the middle value lies on the limit itself.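

In the HEL assay, compound 2 and compound 3 both stand at a limit of the assay rather than a number, so no step between them can be read: the limit of >= 20 ug/mL in the HEL assay, at which 2 of the 3 values shown sit.

In a physicochemical assay for lipophilicity, measured as octanol-water partition (on this read-out lower numbers stand for lower lipophilicity and higher numbers for higher lipophilicity), compound 2 gives 3.26 and compound 3 gives 3.51.

The compounds shown leave open whether hydrogen in place of methoxy on an aromatic carbon alters the reading in the HEL assay at all.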